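From ethoxy to (4-chlorophenyl)amino on a carbonyl carbon

The source may hold more compounds than are shown below. What is called first, only, known or untested is meant among the compounds shown, and "the series" means these compounds.

- Compound 1 `COc1ccc(-n2c(SCC(=O)c3ccc(F)cc3)nnc2-c2cc(OC)c(OC)c(OC)c2)cc1`: 10700 nM
- Compound 2 `COc1ccc(-n2c(SCC(=O)c3ccc(OC)c(O)c3)nnc2-c2cc(OC)c(OC)c(OC)c2)cc1`: > 60000 nM, a limit
- Compound 3 `CCOC(=O)CSc1nnc(-c2cc(OC)c(OC)c(OC)c2)n1-c1ccc(OC)cc1`: > 60000 nM, a limit

In a functional assay on HepG2 cells (Homo sapiens) for inhibition, read by MTT assay, with a stated time of 48 h (on this read-out lower numbers stand for stronger inhibition and higher numbers for weaker inhibition), compound 3 gives no number, only a limit, > 60000 nM. It sits at the limit of > 60000 nM in this assay, at which 2 of the 3 values shown sit. Only compound 1 has a measured number.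

In compound 4 `COc1ccc(-n2c(SCC(=O)Nc3ccc(Cl)cc3)nnc2-c2cc(OC)c(OC)c(OC)c2)cc1`, (4-chlorophenyl)amino stands in place of ethoxy on a carbonyl carbon ((4-chlorophenyl)amino in place of ethoxy on a carbonyl carbon). The shared core stays the same.

Going by the values given here, two measured steps bear on this change. Ethoxy in place of 4-fluorophenyl on a carbonyl carbon gives an at least 5.6-fold higher number from compound 1 to compound 3 (0.74 log units; beyond the scatter). Read in reverse, this suggests that a ring-bearing group at that place can lower the number. Compound 2 goes against that pattern, however, as 3-hydroxy-4-methoxyphenyl in place of 4-fluorophenyl gives an at least 5.6-fold higher number from compound 1 to compound 2 (0.74 log units; beyond the scatter). Among the compounds with values here, no measured compound has the amide hydrogen of compound 4.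

A modest fall in the number is therefore expected in this assay, with a real chance of another limit. Since compound 1 gives 10700 nM, a value near that number is the optimistic end of the expectation. The expected change is an at least 3.0-fold lower number from compound 3 to compound 4 (0.47 log units; beyond the scatter). Compound 4 is estimated at 20000 nM, with an expected range from 6000 nM to 60000 nM.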

Compound 4, half-maximal inhibitory concentration: > 60000 nM
Compound 4: only a limit was reported; the forecaster's own chance of this, stated with the estimate: 30%; at least 3.0-fold (0.47 log units) between middle value and limit.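

Replacing 4-fluorophenyl with (4-chlorophenyl)amino on the carbonyl carbon gives an at least 5.6-fold higher number from compound 1 to compound 4 (0.74 log units; beyond the scatter) in this assay, so a chlorine-bearing aromatic ring reached through an amide nitrogen does not keep the number of compound 1. Together with compound 2, compound 4 shows that a six-membered aromatic ring at this place is not enough on its own to give a measured number, and compound 1 remains the only one of the four that has one. The steps from compound 2 and from compound 3 to compound 4 cannot be read, so no order can be given among these three compounds, which all stop at the same limit: the limit of > 60000 nM in this assay, at which 3 of the 4 values shown sit.

The change in compound 4 alters both the link to the ring and the halogen on it, so the compounds shown do not separate these two differences from compound 1. As far as these compounds go, a 4-chlorophenyl set directly on the carbonyl carbon and a (4-fluorophenyl)amino group at the same place would each change only one of them, and how either behaves remains open.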